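The source may report more compounds than this note shows. Statements on the series, on what has been measured and on what is new or still open speak of the compounds shown alone.

Three related compounds have been measured in a functional assay on HT-29 cells (Homo sapiens) for inhibition, read by sulforhodamine B assay, with a stated time of 48 h (a higher number here means a weaker inhibitor of growth, a lower number a stronger inhibitor of growth), and a fourth awaits measurement. Compound 1 `O=C(CCl)NC(=O)Nc1ccc(OC2CCCCCC2)cc1` carries a cycloheptyl group on an oxygen on an aromatic ring; in this assay compound 1 gives 2300 nM. Compound 2 `O=C(CCl)NC(=O)Nc1cccc(OC2CCCCCC2)c1` is built from the same atoms as compound 1, joined differently, and the difference between the two cores is not broken down here; in this assay compound 2 gives 6900 nM, a number beyond the scatter from compound 1. Compound 3 `O=C(CCl)NC(=O)Nc1ccc(Oc2ccccc2)cc1` differs from compound 1 in a single place, (phenyl in place of cycloheptyl on an oxygen on an aromatic ring). That change made the step of a 1.6-fold higher number from compound 1 to compound 3 (0.19 log units; within the scatter); in this assay compound 3 gives 3600 nM, which lies within the scatter of compound 2.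

Compound 4 `O=C(CCl)NC(=O)Nc1cccc(Oc2ccccc2)c1` is not yet measured. It differs from compound 2 by the same change, (phenyl in place of cycloheptyl on an oxygen on an aromatic ring), at the same place. Among these compounds the change occurs twice, once with both ends measured. For compound 4 a step of about the same size is expected, namely a 1.4-fold higher number from compound 2 to compound 4 (0.16 log units; within the scatter), because the measured step was a 1.6-fold higher number from compound 1 to compound 3 (0.19 log units; within the scatter). This rests on that single measured instance, so the expectation is loose. For compound 4 in this assay the estimated value is 10000 nM, expected to fall between 4000 nM and 25000 nM.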

Compound 4, concentration for 50% growth inhibition: 5200 nM
Beside the measured number, compound 4's estimate is 1.9-fold (0.28 log units) above it, and the stated range covers the measured number.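

In this assay, putting phenyl in place of cycloheptyl on an oxygen on an aromatic ring gives a 1.3-fold lower number from compound 2 to compound 4 (0.12 log units; within the scatter), so on this core too the change stays within the usual spread of repeated measurements. Set against the earlier step on the other core, the two steps point in opposite directions on paper, but they cannot be told apart: the same change on two cores in this assay, a 1.6-fold higher number (0.19 log units; within the scatter) from compound 1 to compound 3 and a 1.3-fold lower number (0.12 log units; within the scatter) from compound 2 to compound 4, 2.1-fold (0.32 log units) apart, within the scatter of two such steps

Going by these compounds alone, this shows that, for these two pairs, the change carried from the core of compound 1 to the core of compound 2 without any step that could be distinguished from scatter, and the apparent flip in direction should not be read as a real reversal; it does not show that phenyl and cycloheptyl are interchangeable on other cores or in other cell lines, since the comparison rests on only two pairs.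

The compounds shown leave open whether a group of a different kind on that oxygen, such as a short methyl, a longer chain, an amine or a carboxylic acid, would move the number beyond the scatter. They also leave open what the same change would do on a core where the chloroacetyl urea part is altered.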